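Moving the chlorine around a pendant phenyl ring

A few compounds are considered here, and "the series" means these few. Any claim that something is new, unique, unknown or untested is made for them only; others in the source may bear on it.

Compound 3 `Oc1ccc(-c2cc(-c3ccc(Cl)cc3)nc(-c3cccs3)c2)cc1` was examined in an assay on isolated protein for inhibition of DNA topoisomerase 1 (Homo sapiens), with a stated time of 30 min, tested at 100 uM (a lower number here means a weaker effect, a higher number a stronger effect of the compound at the concentration tested), where compound 3 gives 38.8%. Among the three measured compounds it holds the second highest number: compound 2 `Oc1ccc(-c2cc(-c3cccc(Cl)c3)nc(-c3ccccn3)c2)cc1` gives 59.4%, and compound 1 `Oc1ccc(-c2cc(-c3cccs3)nc(-c3ccccc3Cl)c2)cc1` gives 2.2%. For the measured compounds named here, only one step between measured compounds can be traced directly, and it concerns the same chlorophenyl ring: a number 36.6 percentage points higher from compound 1 to compound 3 (beyond the scatter), a large change. Compound 4 `Oc1ccc(-c2cc(-c3cccc(Cl)c3)nc(-c3cccs3)c2)cc1` is built from compound 3 by another move of the chlorine on that ring: 3-chlorophenyl in place of 4-chlorophenyl on an aromatic carbon. Going by the values given here, no measured pair repeats exactly this move. Compound 2, which also carries a 3-chlorophenyl group, gives the highest number of the three with 59.4%, though it differs from compound 4 elsewhere, so it serves only as a loose pointer. The expectation is therefore a modest rise in this assay, possibly none beyond the scatter. Compound 4 is expected to give 46%, within 22% to 70%. The expected step of a number 7.2 percentage points higher from compound 3 to compound 4 (within the scatter) is small.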

Compound 4, a percentage reported as inhibition, at one concentration (the size of the read-out at that concentration, not a potency): 52.4%
Estimate against measurement, compound 4: 6.4 percentage points below; low and high end bracket the measured number.
By their numbers in this assay, from the lowest: compound 1; then compound 3; then compounds 4 and 2 (each within the scatter of the next).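

With the chlorine now read at all three places on the same core, a number 50.2 percentage points higher from compound 1 to compound 4 (beyond the scatter) and a number 13.6 percentage points higher from compound 3 to compound 4 (beyond the scatter), so in this assay the 3-chlorophenyl group stands above both the 2-chlorophenyl and the 4-chlorophenyl groups, and the place of one chlorine atom is enough to separate these three compounds. With 3-chlorophenyl held constant, thiophen-2-yl in place of pyridin-2-yl gives a number 7 percentage points lower from compound 2 to compound 4 (within the scatter), so the two cannot be told apart in this read-out. Nothing at hand explains why the place of the chlorine matters here.

Going by these compounds, whether a methoxy group or an amine in place of the chlorine on that ring would keep the number stays open. So does whether the same order of chlorine places holds with pyridin-2-yl in place of thiophen-2-yl.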